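This account rests on a few compounds, and the source may have more. Where it says the series, first, only, none or still open, it means among the compounds named here.

The study measures cytotoxicity in a functional assay on QGY7701 cells (Homo sapiens) for cytotoxicity, read by MTT assay, with a stated time of 24 h; a higher number here means a weaker inhibitor, a lower number a stronger inhibitor. Compound 1, `C=CC1=C(C(=O)NC2CCCCC2)C(c2ccc(F)cc2)OC1`, carries a cyclohexyl amide and a fluoro group; in this assay compound 1 gives 40500 nM. Compound 2, `C=CC1=C(C(=O)NCC(C)C)C(c2ccc(OC)cc2)OC1`, carries an isobutyl amide and a methoxy group. In this assay compound 2 returns only a limit, > 100000 nM, so its value is not known as a number. Compound 2 therefore stands at the limit of > 100000 nM in this assay, at which 1 of the 2 values shown sits, the upper edge of what the assay reports. Compound 3, `C=CC1=C(C(=O)NCC(C)C)C(c2ccc(F)cc2)OC1`, differs from compound 2 by a single change: fluoro in place of methoxy on an aromatic carbon. Within the data shown here, no measured pair turns on this change alone, so the expectation rests on compound 1 and compound 2 together. Since compound 1, which also carries fluoro, gives 40500 nM, compound 3 is expected to land near 60000 nM, with a plausible range from 25000 nM to 150000 nM. That estimate means an expected step from compound 2 to compound 3 of an at least 1.6-fold lower number from compound 2 to compound 3 (0.22 log units; that floor lies within the scatter), toward stronger inhibition, with a real chance that compound 3 again returns only a limit.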

Compound 3, half-maximal inhibitory concentration: > 100000 nM
Compound 3 ended at the assay's limit (the forecaster's own chance of this, stated with the estimate: 40%); at least 1.6-fold (0.22 log units) between middle value and limit.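

Compound 3 in this assay is again only a limit of the assay, > 100000 nM, so fluoro in place of methoxy on this aromatic carbon does not by itself bring the isobutyl amide to a readable value. The size of that step cannot be read, because both compounds sit at the same limit: the limit of > 100000 nM in this assay, at which 2 of the 3 values shown sit.

Among these compounds, with fluoro held in place, the new comparison falls on the amide instead: isobutyl in place of cyclohexyl on the amide-type nitrogen gives an at least 2.4-fold higher number from compound 1 to compound 3 (0.39 log units; beyond the scatter), the first readable step in this set.

On these data alone, how far compound 2 and compound 3 lie past the limit remains open, as does whether methoxy would keep a readable value alongside a cyclohexyl amide. Also open, as far as these compounds go, is how a chloro group on the aromatic carbon, or a longer chain on the amide-type nitrogen, would read.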